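A fluorinated alcohol chain on a slowly cleared compound

This account rests on a few compounds, and the source may have more. Where it says the series, first, only, none or still open, it means among the compounds named here.

- Compound 1 `CCOc1ccc(OC(F)(F)F)cc1Cn1c(C(=O)NCC(C)(C)CO)cc2cc(C#N)ccc21`: 20 mL.min-1.g-1
- Compound 2 `CC(C)(O)CCNC(=O)c1cc2cc(C#N)ccc2n1Cc1cccc(OC(F)(F)F)c1`: < 6 mL.min-1.g-1

In an in vitro ADME assay on microsomes from liver (Homo sapiens) for metabolic stability, in the presence of a further agent that is not named here (on this read-out lower numbers stand for slow clearance and higher numbers for fast clearance), compound 2 gives < 6 mL.min-1.g-1, which is a limit and not a number. Compound 3 `N#Cc1ccc2c(c1)cc(C(=O)NCCC(O)(C(F)(F)F)C(F)(F)F)n2Cc1cccc(OC(F)(F)F)c1` differs from compound 2 in one place on the amide chain: 2,2,2-trifluoro-1-hydroxy-1-(trifluoromethyl)ethyl in place of 1-hydroxy-1-methylethyl on a saturated chain carbon, two bonds along the chain from an amide-type nitrogen. For the measured compounds named here, no measured pair of compounds shows what this change does. The expected result is a small rise in clearance, possibly no larger than the scatter, with an estimated at least 1.3-fold higher number from compound 2 to compound 3 (0.12 log units; that floor lies within the scatter). For compound 3, the estimated clearance is 8 mL.min-1.g-1, with an expected range of 4 mL.min-1.g-1 to 25 mL.min-1.g-1.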

Compound 3, intrinsic clearance in microsomes: 24 mL.min-1.g-1
For compound 3 the middle estimate is 3.0-fold (0.48 log units) below the measured one; low and high end bracket the measured number.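

On the amide chain, 2,2,2-trifluoro-1-hydroxy-1-(trifluoromethyl)ethyl in place of 1-hydroxy-1-methylethyl gives an at least 4.0-fold higher number from compound 2 to compound 3 (0.60 log units; beyond the scatter) in this assay. For the compounds shown here, this is the first sign that clearance responds to a change at this position, and here the fluorinated group goes with the higher number. The figure for compound 2 is a limit, so the step is only a floor and its full size stays unknown: the limit of < 6 mL.min-1.g-1 in this assay, at which 1 of the 3 values shown sits.

Still open, as far as these compounds go, is whether a single trifluoromethyl group on this chain would give a smaller step. Also open, from the compounds shown here alone, is how an amine or a carboxylic acid at this place would read.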